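Moving a fluorine on the aryl amide of a prostaglandin antagonist

The source may hold more compounds than are shown below. What is called first, only, known or untested is meant among the compounds shown, and "the series" means these compounds.

Measured so far:
compound 1 `O=C(O)CCC(=O)N(C1CC1)[C@H]1c2ccccc2N(C(=O)c2cccc(OC(F)(F)F)c2)[C@H]2CC[C@H]21`: 18 nM
compound 2 `O=C(O)CCC(=O)N(C1CC1)[C@H]1c2ccccc2N(C(=O)c2ccc(F)cc2)[C@H]2CC[C@H]21`: 8.9 nM

In a functional assay for antagonist activity at prostaglandin D2 receptor 2 (Homo sapiens), read by flow cytometry, with stated times of 10 min and 4 min (on this read-out lower numbers stand for stronger inhibition and higher numbers for weaker inhibition), compound 2 gives the lowest number of the two, and its nearest neighbour is compound 1, separated by a 2.0-fold lower number from compound 1 to compound 2 (0.31 log units; beyond the scatter). Compound 3 `O=C(O)CCC(=O)N(C1CC1)[C@H]1c2ccccc2N(C(=O)c2cccc(F)c2)[C@H]2CC[C@H]21` keeps the shared core of compound 2 and differs only in the aryl group: 3-fluorophenyl in place of 4-fluorophenyl on a carbonyl carbon. Among the compounds with values here, no measured step moves a fluorine around the ring, so the only guide is the modest swing seen in a 2.0-fold lower number from compound 1 to compound 2 (0.31 log units; beyond the scatter). Compound 3 is therefore expected to stay close to compound 2, with a 1.3-fold higher number from compound 2 to compound 3 (0.13 log units; within the scatter) not clearly beyond the scatter. The estimate for compound 3 is 12 nM, ranging from 5 nM to 30 nM.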

Compound 3, half-maximal inhibitory concentration: 14 nM
Estimate against measurement, compound 3: 1.2-fold (0.07 log units) below, and the stated range covers the measured number.
By their numbers in this assay, from the lowest: compounds 2, 3 and 1 (each within the scatter of the next, the first and the last beyond it).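

Swapping 4-fluorophenyl for 3-fluorophenyl on the carbonyl carbon gives a 1.6-fold higher number from compound 2 to compound 3 (0.20 log units; within the scatter) in this assay, so this read-out does not separate the two fluorine placements. Fluoro in place of trifluoromethoxy on the aromatic carbon gives a 1.3-fold lower number from compound 1 to compound 3 (0.11 log units; within the scatter), so compound 3 cannot be told apart from either neighbour, even though compound 1 and compound 2 do stand apart. Nothing available explains these numbers. On these data alone, how an unsubstituted phenyl or an aminophenyl would read on this carbonyl carbon remains open.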